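Sulfamoyl in Place of Methoxy: Expected Inhibition of Compound 3

The compounds below may be only part of what the source reports. "The series", "measured", "known", "first", "only" and "open" are said of these compounds alone.

Compound 1 `CCOc1nc2cccc(C(=O)NCCCOC)c2n1Cc1ccc(-c2ccccc2-c2nnn[nH]2)cc1`: 27.9%
Compound 2 `CCOc1nc2cccc(C(=O)Nc3ccc(OC)cc3)c2n1Cc1ccc(-c2ccccc2-c2nnn[nH]2)cc1`: 25.8%

In an assay on isolated protein for inhibition of NEDD8-activating enzyme E1 regulatory subunit (Homo sapiens), read by Western blot, with stated times of 10 min and 30 min, tested at 25 uM (a lower number here means less inhibition, a higher number more inhibition at the concentration tested (going by the name of the read-out)), compound 1 gives 27.9% and compound 2 gives 25.8%. Compound 2 has the lower of the two numbers, yet the step of a number 2.1 percentage points lower from compound 1 to compound 2 (within the scatter) lies within the scatter, so the two cannot be told apart. Compound 3 `CCOc1nc2cccc(C(=O)Nc3ccc(S(N)(=O)=O)cc3)c2n1Cc1ccc(-c2ccccc2-c2nnn[nH]2)cc1` differs from compound 2 by sulfamoyl in place of methoxy on an aromatic carbon. Going by the values given here, the only measured step replaces the whole group on the amide nitrogen, not a substituent on the aromatic ring, and is within the scatter; it offers little guidance, so no step beyond the scatter is expected, a number 2.2 percentage points higher from compound 2 to compound 3 (within the scatter). Compound 3 is therefore estimated at 28%, with a range from 14% to 44%.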

Compound 3, a percentage reported as inhibition, at one concentration (the size of the read-out at that concentration, not a potency): 60.9%
Beside the measured number, compound 3's estimate is 32.9 percentage points below it, outside the stated range (above it).
By their numbers in this assay, from the lowest: compounds 2 and 1 (each within the scatter of the next); then compound 3.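

In this assay, the group at the far end of the aromatic ring matters: sulfamoyl in place of methoxy gives a number 35.1 percentage points higher from compound 2 to compound 3 (beyond the scatter) and places compound 3 clear of both earlier compounds. The 4-sulfamoylphenyl group on the amide nitrogen also gives a number 33 percentage points higher from compound 1 to compound 3 (beyond the scatter) against 3-methoxypropyl, while compound 1 and compound 2 could not be told apart, so an aromatic ring on that nitrogen does not by itself set the number. Nothing available explains why sulfamoyl gives this gain.

As far as these compounds go, whether a carboxylic acid or an amine at the same ring position would give a similar number remains open. So does whether adding a methyl group to the sulfamoyl nitrogen would keep the gain.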